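This account rests on a few compounds, and the source may have more. Where it says the series, first, only, none or still open, it means among the compounds named here.

Compounds measured in a functional assay on L1210 cells (Mus musculus); a lower number here means that less compound is needed, a higher number that more compound is needed for the effect:
compound 1, `O=c1ccn([C@@H]2O[C@H](CO)C[C@@H]2O)c(=O)[nH]1`, gives a limit, > 100 uM.
compound 2, `O=c1ccn([C@@H]2O[C@H](CO)C[C@H]2O)c(=O)[nH]1`, gives 50 uM.
compound 3, `CC(=O)OC[C@@H]1C[C@H](OC(C)=O)[C@H](n2ccc(N)nc2=O)O1`, gives 20 uM.

The value of compound 1 is a limit of this assay rather than a number. Compound 3 stands at the lowest of the two numbers shown, and its gap to compound 2 lies beyond the usual scatter. Among the measured compounds shown here, the only step between compounds that differ in a single place is an at least 2.0-fold lower number from compound 1 to compound 2 (0.30 log units; that floor lies within the scatter), and it rests on the fact that compounds 1 and 2 differ only in the configuration as drawn: a change of configuration alone, not of atoms or bonds.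

Compound 4, `CC(=O)OC[C@@H]1C[C@H](O)[C@H](n2ccc(N)nc2=O)O1`, is compound 3 with one change: hydrogen in place of acetyl on an oxygen on a saturated carbon. For the measured compounds named here, no measured step here removes an acetyl, so there is no direct guide for the size or direction of this change. Compound 4 is therefore expected to stay close to compound 3, with no change at the digits printed from compound 3 to compound 4 (within the scatter) as the estimated step and a wide range allowed. The estimate for compound 4 in this assay is 20 uM, between 4 uM and 100 uM.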

Compound 4, concentration for half-maximal effect: 3 uM
Compound 4: middle estimate off by 6.7-fold (0.82 log units), on the high side, outside the stated range (below it).
By their numbers in this assay, from the lowest: compound 4; then compound 3; then compound 2. At a limit, above all of these: compound 1.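

In this assay, among the compounds shown here, the change of acetoxy to hydroxy gives a 6.7-fold lower number from compound 3 to compound 4 (0.82 log units; beyond the scatter), the first step here that alters atoms rather than configuration alone. It shows that the number responds to what is carried on this oxygen on a saturated carbon, and that with hydrogen in place of acetyl, less compound is needed for the effect. Nothing measured here bears on why this step occurs.

The compounds shown leave open whether another group on this oxygen, such as a methyl or a longer acyl chain like butyryl, would lower the number further or raise it again. They also leave open what happens when the acetyl that compound 4 still carries on its other oxygen is replaced by hydrogen as well.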